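This account rests on a few compounds, and the source may have more. Where it says the series, first, only, none or still open, it means among the compounds named here.

Working notes on the series

Three compounds carry the same sulfonyl-linked cyclopropyl-oxazole arm and a fused bicyclic core. Compound 1 `O=S(=O)(c1ccc(-c2cnc(C3CC3)o2)cc1)N1CCCOc2cc(F)ccc21` gives 65 nM in a functional assay on HepG2 cells (Homo sapiens) for antiproliferative activity, read by MTT assay, with a stated time of 72 h; a lower number here means a stronger inhibitor, a higher number a weaker inhibitor. Compound 2 `O=[N+]([O-])c1ccc2c(c1)OCCCN2S(=O)(=O)c1ccc(-c2cnc(C3CC3)o2)cc1` gives 71 nM in this assay. Compound 3 `O=[N+]([O-])c1ccc2c(c1)N(S(=O)(=O)c1ccc(-c3cnc(C4CC4)o3)cc1)CCCO2` gives 149 nM in this assay, the highest number of the three.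

Compound 2 and compound 3 have the same atoms joined differently; the difference between the two cores is not broken down here. Their numbers are separated by a gap described as beyond the scatter.

The change fluoro in place of nitro on an aromatic carbon gave a 1.1-fold lower number from compound 2 to compound 1 (0.04 log units; within the scatter).

Compound 4 `O=S(=O)(c1ccc(-c2cnc(C3CC3)o2)cc1)N1CCCOc2ccc(F)cc21` is not yet measured. It differs from compound 3 by fluoro in place of nitro on an aromatic carbon, the same change as from compound 2 to compound 1, at a place described in the same words. Among the measured compounds shown here, the step of a 1.1-fold lower number from compound 3 to compound 4 (0.04 log units; within the scatter) is expected to be small, resting on the single earlier instance, the step of a 1.1-fold lower number from compound 2 to compound 1 (0.04 log units; within the scatter). Compound 4 is therefore estimated at 135 nM in this assay, with a plausible range from 60 nM to 300 nM.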

Compound 4, half-maximal inhibitory concentration: 36 nM
For compound 4 the middle estimate is 3.8-fold (0.57 log units) above the measured one; the whole stated range lies above it.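

Fluoro in place of nitro on an aromatic carbon gives a 4.1-fold lower number from compound 3 to compound 4 (0.62 log units; beyond the scatter) in this assay, so this change does not carry a single step size from one core to the other, and the two instances differ: the same change on two cores in this assay, a 1.1-fold lower number (0.04 log units; within the scatter) from compound 2 to compound 1 and a 4.1-fold lower number (0.62 log units; beyond the scatter) from compound 3 to compound 4, 3.8-fold (0.58 log units) apart, beyond the scatter of two such steps.

The near-absence of a shift on the core of compound 2 therefore gave no reliable guide to the size of the step on the core of compound 3, although the number is lower with fluoro in both pairs. The two pairs show only that the size of the step depends on the core in these compounds; they do not show which feature of the cores is responsible, nor how the change would behave on any further core.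

With only nitro and fluoro shown, it remains open whether an amine, a methoxy group or a carboxylic acid on the same aromatic carbons would follow the smaller or the larger step. As far as these compounds go, it also remains open whether the two steps would keep their difference in another cell line.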